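A Tert-Butyl for Methoxy on a Carbonyl Carbon

The source may report more compounds than this note shows. Statements on the series, on what has been measured and on what is new or still open speak of the compounds shown alone.

In a functional assay on L5178Y cells (Mus musculus) for inhibition, read by MTT assay, with a stated time of 72 h (on this read-out higher numbers stand for weaker inhibition and lower numbers for stronger inhibition), two compounds have been measured so far. Compound 1 (`O=C1[Se]C(=O)c2ccccc21`) gives 4650 nM and compound 2 (`COC(=O)C[Se]C(=O)c1ccc(Cl)cc1`) gives 87800 nM as the higher of the two numbers. Compound 2 is thus the weaker inhibitor, and its gap to compound 1 lies beyond the usual scatter. Compound 3 (`CC(C)(C)C(=O)C[Se]C(=O)c1ccc(Cl)cc1`) has not yet been measured. Relative to compound 2 it carries tert-butyl in place of methoxy on a carbonyl carbon. Among the measured compounds shown here, the two measured compounds do not differ in just one place, so no measured step speaks directly to this change. The estimated step of a 2.9-fold lower number from compound 2 to compound 3 (0.47 log units; beyond the scatter) is a moderate one toward stronger inhibition, and it is held with little confidence. Compound 3 is expected at 30000 nM (estimated range 6000 nM to 120000 nM).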

Compound 3, half-maximal inhibitory concentration: 430 nM
Estimate against measurement, compound 3: 70-fold (1.84 log units) above, outside the stated range (below it).
By their numbers in this assay, from the lowest: compound 3; then compound 1; then compound 2.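

Among the compounds shown here, the exchange of methoxy for tert-butyl on a carbonyl carbon is the only single-place change available here, and in this assay it gives a 200-fold lower number from compound 2 to compound 3 (2.31 log units; beyond the scatter), which shows that inhibition depends strongly on the group at this position. The change leaves a group holding one hydrogen-bond acceptor for one of four carbons with none, so heavy-atom count and acceptor count shift together and this one step cannot separate them. Nothing available explains the size of the step.

From the compounds shown here alone, it remains open whether a group such as isopropyl, cyclopropyl, phenyl or an amine on the same carbonyl carbon would keep this gain. Going by these compounds, it is also open whether the step would hold if the chloro group were replaced by hydrogen or methyl.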